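Compound 3 gives up its 2-oxopiperidin-4-yl group

The source may hold more compounds than are shown below. What is called first, only, known or untested is meant among the compounds shown, and "the series" means these compounds.

In an ADME assay on microsomes from liver (Mus musculus, strain CD-1) for metabolic stability, read by LC-MS, tested at 2 uM (a higher number here means that the compound lasts longer, a lower number that the compound disappears faster), compound 1 `CN(C)C(=O)c1ccncc1Nc1cc(-c2ccc3ccn(C)c3c2)c2nccnc2c1` gives 0.35 h and compound 2 `Cn1ccc2ccc(-c3cc(Nc4cnccc4C(=O)NCc4cncnc4)cc4nccnc34)cc21` gives 0.4 h, so that a 1.1-fold higher number from compound 1 to compound 2 (0.06 log units; within the scatter) changes little. Compound 3 `Cn1ccc2ccc(-c3cc(Nc4cnccc4C(=O)NC4CCNC(=O)C4)cc4nccnc34)cc21` reads > 1 h, which is a limit and not a number, and it stands at the limit of > 1 h in this assay, at which 1 of the 3 values shown sits. The two steps that lead to it are an at least 2.8-fold higher number from compound 1 to compound 3 (0.45 log units; beyond the scatter) and an at least 2.5-fold higher number from compound 2 to compound 3 (0.39 log units; beyond the scatter). Among these compounds, only compound 3 carries 2-oxopiperidin-4-yl, and only the steps to it go beyond the scatter. Compound 4 `CC(=O)N1CCOC(CNC(=O)c2ccncc2Nc2cc(-c3ccc4ccn(C)c4c3)c3nccnc3c2)C1` keeps the shared core but has (4-acetylmorpholin-2-yl)methyl in place of 2-oxopiperidin-4-yl on an amide-type nitrogen. Going by the values given here, the group that came with an at least 2.5-fold higher number from compound 2 to compound 3 (0.39 log units; beyond the scatter) is therefore lost, so part of that gain is expected to go as well, though no measured step tests the entering group. A move toward a lower number is expected, an at least 1.6-fold lower number from compound 3 to compound 4 (0.22 log units; that floor lies within the scatter). For compound 4 the estimate is 0.6 h, with an expected range of 0.3 h to 1.2 h.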

Compound 4, half-life: 0.217 h
Estimate against measurement, compound 4: 2.8-fold (0.44 log units) above, and the stated range ends above it.
By their numbers in this assay, from the lowest: compounds 4, 1 and 2 (each within the scatter of the next). At a limit, above all of these: compound 3.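

Going by these compounds alone, compound 3 remains the only compound read at a limit in this assay, and that reading is a limit and not a number: the limit of > 1 h in this assay, at which 1 of the 4 values shown sits. On the amide-type nitrogen, (4-acetylmorpholin-2-yl)methyl gives an at least 4.6-fold lower number from compound 3 to compound 4 (0.66 log units; beyond the scatter), whereas the comparisons with the other two compounds, a 1.8-fold lower number from compound 2 to compound 4 (0.27 log units; within the scatter) and a 1.6-fold lower number from compound 1 to compound 4 (0.21 log units; within the scatter), stay within the scatter. The entering group keeps a six-membered non-aromatic ring and a double bond outside aromatic rings, so among these compounds those features alone do not preserve the reading of compound 3.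

As far as these compounds go, whether that reading depends on the hydrogen-bond donor of 2-oxopiperidin-4-yl, on the extra methyl or on the acetyl group stays open. A piperidin-4-yl amine or an unacetylated morpholin-2-ylmethyl group would bear on this, and how far compound 3 lies past its limit is also unresolved.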